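A few compounds are considered here, and "the series" means these few. Any claim that something is new, unique, unknown or untested is made for them only; others in the source may bear on it.

Measured in an assay for inhibition of beta-glucuronidase (Bos taurus), read by spectrophotometry, with a stated time of 30 min; a lower number here means a stronger inhibitor, a higher number a weaker inhibitor:

Compound 1, `COC(=O)C1=C(C)NC(=O)NC1c1ccc(O)cc1`: 17200 nM
Compound 2, `CCC1NC(=O)NC(C)=C1C(=O)OC`: 52200 nM
Compound 3, `COC(=O)C1=C(C)NC(=O)NC1CC(C)C`: 55200 nM

Compound 1 gives the lowest number of the three; compounds 2 and 3 both sit higher, by more than the scatter, and their values lie close to each other. For the measured compounds named here, the only step measured between two compounds, a 1.1-fold higher number from compound 2 to compound 3 (0.02 log units; within the scatter), concerns a saturated chain on the shared core, not the aromatic ring.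

Compound 4, `COC(=O)C1=C(C)NC(=O)NC1c1ccc(N(C)C)cc1`, differs from compound 1 by dimethylamino in place of hydroxy on an aromatic carbon. Going by the values given here, no measured step touches a group on that aromatic ring, so nothing here tells the direction of this change. The expectation is therefore a step of a 1.3-fold higher number from compound 1 to compound 4 (0.11 log units; within the scatter), not beyond the scatter. Compound 4 is estimated at 22000 nM, within a range from 7000 nM to 70000 nM.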

Compound 4, half-maximal inhibitory concentration: 49200 nM
Compound 4: the middle estimate sits 2.2-fold (0.35 log units) below what was measured, within the range that was stated.
By their numbers in this assay, from the lowest: compound 1; then compounds 4, 2 and 3 (each within the scatter of the next).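

Swapping hydroxy for dimethylamino on an aromatic carbon gives a 2.9-fold higher number from compound 1 to compound 4 (0.46 log units; beyond the scatter) in this assay and so shows that this position is not indifferent to the group it carries. The swap removes the hydrogen-bond donor of the hydroxy and adds heavy atoms, and no measurement available here separates these two differences. Still open, as far as these compounds go, is whether a plain amine or a methoxy group in the same place would stay close to compound 1 or move as far as compound 4.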